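Indolyl for furanyl at the limit of hepatic cytotoxicity

A few compounds are considered here, and "the series" means these few. Any claim that something is new, unique, unknown or untested is made for them only; others in the source may bear on it.

Compound 1 `CC(C)N(Cc1cccc(OCCCCCC(=O)O)c1)C(=O)c1ccc(-c2ccoc2)cc1` was tested in an ADME assay on HepG2 cells (Homo sapiens) for cytotoxicity, read by CellTiter-Glo and resazurin assay, with a stated time of 72 h; on this read-out higher numbers stand for an effect only at larger amounts of compound and lower numbers for an effect already at smaller amounts. In this assay compound 1 gives only a limit, > 26000 nM, not a number. Compound 2 `CC(C)N(Cc1cccc(OCCCCCC(=O)O)c1)C(=O)c1ccc(-c2cccc(OCc3ccccc3)c2)cc1` shares the same core, and in this assay compound 2 likewise gives only a limit, > 26000 nM. Both measured values sit together at the limit of > 26000 nM in this assay, at which 2 of the 2 values shown sit, so compound 1 cannot be placed higher or lower than compound 2 on the numbers shown. Compound 3 `CC(C)N(Cc1cccc(OCCCCCC(=O)O)c1)C(=O)c1ccc(-c2ccc3cc[nH]c3c2)cc1` has not yet been measured in this assay. It differs from compound 1 by 1H-indol-6-yl in place of furan-3-yl on an aromatic carbon. Going by the values given here, with no measured step to draw on, and both measured compounds at the limit, a move beyond the scatter in either direction is not expected, and the most likely outcome for compound 3 is again a limit. Compound 3 is therefore expected to give 26000 nM in this assay, between 12000 nM and 60000 nM, which amounts to an expected step of a number no higher from compound 1 to compound 3 (the limit leaves the size open).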

Compound 3, half-maximal effective concentration: > 26000 nM
Compound 3: only a limit was reported; the forecaster's own chance of this, stated with the estimate: 80%; the middle value lies on the limit itself.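

Going by these compounds alone, compound 3, like compound 1, gives only a limit in this assay, so no step between them can be read: the limit of > 26000 nM in this assay, at which 3 of the 3 values shown sit. The compounds shown leave open where each would reach its half-maximal effect, and whether 1H-indol-6-yl in place of furan-3-yl shifts that concentration at all.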